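Compound 2 to compound 3: a new aromatic group

A few compounds are considered here, and "the series" means these few. Any claim that something is new, unique, unknown or untested is made for them only; others in the source may bear on it.

Measured in a functional assay on A549 cells (Homo sapiens) for antiproliferative activity, read by MTT assay, with a stated time of 72 h; a higher number here means a weaker inhibitor, a lower number a stronger inhibitor:
- compound 1 `C#Cc1cccc(Nc2ncnc3cc(OC)c(OCCCN4CCNCCNCCNCC4)cc23)c1`: 28600 nM
- compound 2 `COc1cc2ncnc(Nc3cccc(I)c3)c2cc1OCCCN1CCNCCNCCNCC1`: 14500 nM

Compound 2, at 14500 nM, cannot be told apart from compound 1, as the two numbers lie within the usual scatter of repeated measurements. For the measured compounds named here, only one measured step is available: a 2.0-fold lower number from compound 1 to compound 2 (0.29 log units; within the scatter), with iodo in place of ethynyl on an aromatic carbon.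

The next structure, compound 3 `CCc1cc(Br)ccc1Nc1ncnc2cc(OC)c(OCCCN3CCNCCNCCNCC3)cc12`, keeps the rest of compound 2 but changes one group: 4-bromo-2-ethylphenyl in place of 3-iodophenyl on a nitrogen on an aromatic ring. The measured step also concerns a group on that aromatic ring, yet it is a single swap and stays within the scatter. It offers only weak guidance for a larger change, so no step beyond the scatter is expected in this assay, and the range is kept wide. Compound 3 is estimated at 20000 nM, with an expected range of 7000 nM to 50000 nM. The expected change is a 1.4-fold higher number from compound 2 to compound 3 (0.14 log units; within the scatter).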

Compound 3, half-maximal inhibitory concentration: > 50000 nM
Compound 3: only a limit was reported; the forecaster's own chance of this, stated with the estimate: 12%; middle value at least 2.5-fold (0.39 log units) from the limit.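

In this assay, compound 3 gives > 50000 nM, which is a limit of the assay and not a number: the limit of > 50000 nM in this assay, at which 1 of the 3 values shown sits. Even so, the aromatic group on the nitrogen is the first place in this set where a change clearly moves the result, with an at least 3.4-fold higher number from compound 2 to compound 3 (0.53 log units; beyond the scatter), whereas the earlier swap of iodo for ethynyl stayed within the scatter. For the compounds shown here, the comparison with the ethynyl compound is less firm, with an at least 1.7-fold higher number from compound 1 to compound 3 (0.24 log units; that floor lies within the scatter), so only the step from the iodo compound clears the scatter.

The step changes the whole group at once, so the compounds shown cannot tell whether the ethyl, the bromine or their placement on the ring accounts for it. As far as these compounds go, how a plain phenyl, or a phenyl carrying only the ethyl or only the bromine, would read on that nitrogen stays open.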